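The source may hold more compounds than are shown below. What is called first, only, known or untested is meant among the compounds shown, and "the series" means these compounds.

Measured compounds in a functional assay on MIA PaCa-2 cells (Homo sapiens) for inhibition, read by MTT assay, with a stated time of 7 days; on this read-out lower numbers stand for stronger inhibition and higher numbers for weaker inhibition:
compound 1, `CCN(CC)S(=O)(=O)c1ccc(S(=O)(=O)N2CCC[C@@H](C(=O)NC3CN(C(=O)OC(C)(C)C)C3)C2)cc1`: 200 nM
compound 2, `CCOC(=O)N1CCC[C@H](S(=O)(=O)c2ccc(S(=O)(=O)N(CC)CC)cc2)C1`: this compound reaches only a limit of the assay, > 30000 nM
compound 3, `CC(C)c1noc(N2CCN(C(=O)[C@@H]3CCCN(S(=O)(=O)c4ccc(S(=O)(=O)NC5CC5)cc4)C3)CC2)n1`: 1000 nM

Compound 3 stands at the highest of the two numbers that this assay yields among these three compounds. Its nearest neighbour is compound 1, whose number is lower by a margin that lies beyond the usual scatter, so compound 1 is the more potent of the two. The third value is not a number at all: the limit of > 30000 nM in this assay, at which 1 of the 3 values shown sits, and compound 2 is the one sitting there.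

Compound 4 `CCN(CC)C(=O)c1ccc(S(=O)(=O)N2CCC[C@@H](C(=O)N3CCN(c4nc(C(C)C)no4)CC3)C2)cc1` is the next compound for this assay. It differs from compound 3 in a single place: diethylcarbamoyl in place of cyclopropylsulfamoyl on an aromatic carbon. Going by the values given here, no pair among the measured compounds isolates this change, so there is no measured step to lean on. The expectation for compound 4 is therefore a step from compound 3 of modest size in this assay, with no firm direction, and most likely within the scatter. On that basis compound 4 is estimated at 800 nM, between 200 nM and 4000 nM, which means an expected step of a 1.3-fold lower number from compound 3 to compound 4 (0.10 log units; within the scatter).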

Compound 4, half-maximal inhibitory concentration: 100 nM
For compound 4 the middle estimate is 8.0-fold (0.90 log units) above the measured one; measured number below the stated range.
By their numbers in this assay, from the lowest: compounds 4 and 1 (each within the scatter of the next); then compound 3. At a limit, above all of these: compound 2.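

In this assay, going by these compounds alone, placing diethylcarbamoyl instead of cyclopropylsulfamoyl on the aromatic carbon para to a large group gives a 10-fold lower number from compound 3 to compound 4 (1.00 log units; beyond the scatter), the first measured step at this position. It shows that, with the rest of the molecule unchanged, the number responds clearly to this exchange: the group that leaves carries 1 hydrogen-bond donor and a three-membered ring, while the group that enters has 0 hydrogen-bond donors and no ring. No measurement shown here accounts for the size of this step.

This single pair does not separate the loss of the donor, the loss of the ring and the exchange of the sulfamoyl for a carbamoyl from one another. Going by these compounds, how a dipropylcarbamoyl group, a carboxylic acid or an amine would fare at this position remains open.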